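The source may report more compounds than this note shows. Statements on the series, on what has been measured and on what is new or still open speak of the compounds shown alone.

In a functional assay on the whole organism with Rattus norvegicus as the target (on this read-out higher numbers stand for an effect only at larger amounts of compound and lower numbers for an effect already at smaller amounts), three compounds have been measured so far. Compound 1 `CCCCCc1ccc2nc(N)sc2c1` gives 7.5 mg/kg. Compound 2 `Nc1nc2cc(OC(F)(F)F)ccc2s1` gives > 10 mg/kg, which is a limit of this assay and not a number. Compound 3 `CCCn1c(=N)sc2cc(OC(F)(F)F)ccc21` gives 4.5 mg/kg, and this value lies within the usual scatter of the value for compound 1, so the two cannot be told apart. Among the compounds with values here, they are the only two true numbers available here.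

The next compound to be tested is compound 4 `N=c1sc2cc(OC(F)(F)F)ccc2n1CC(N)=O`. It differs from compound 3 in one place, with carbamoyl in place of ethyl on a saturated chain carbon bound to an aromatic nitrogen. Cut one bond further out, the same change reads propyl to carbamoylmethyl. Within the data shown here, no two measured compounds differ in only one place, so the data do not show directly what a swap of this kind does. The forecast therefore rests on compound 3 at 4.5 mg/kg as its anchor, and it is a cautious judgement with a wide range. A moderate shift towards larger doses is expected, about the size of the scatter or slightly more. The expected step is a 2.0-fold higher number from compound 3 to compound 4 (0.30 log units; within the scatter). For compound 4 the estimate is 9 mg/kg, with an expected range from 3.5 mg/kg to 25 mg/kg.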

Compound 4, dose for half-maximal effect: 7 mg/kg
Compound 4: the middle estimate sits 1.3-fold (0.11 log units) above what was measured; low and high end bracket the measured number.
By their numbers in this assay, from the lowest: compounds 3, 4 and 1 (each within the scatter of the next). At a limit, above all of these: compound 2.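

Within the data shown here, the swap of ethyl for carbamoyl on a saturated chain carbon bound to an aromatic nitrogen gives the first direct reading of a single change. In this assay, the result is a 1.6-fold higher number from compound 3 to compound 4 (0.19 log units; within the scatter). The incoming carbamoyl brings one more heavy atom than the ethyl it replaces, along with a nitrogen, an oxygen, a hydrogen-bond donor and a hydrogen-bond acceptor, yet propyl and carbamoylmethyl cannot be told apart at this place, so on this read-out the position accepts a clear change in the make-up of the chain without a difference that stands out from the scatter.

This remains a single step at a single place, and it gives no trend: whether an amine or a carboxylic acid on the same chain carbon, or a longer chain ending in the carbamoyl, would also stay within the scatter is open. The series also offers one reading that is a limit of the assay and not a number, which gives no size for any comparison: the limit of > 10 mg/kg in this assay, at which 1 of the 4 values shown sits.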